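The source may hold more compounds than are shown below. What is called first, only, known or untested is meant among the compounds shown, and "the series" means these compounds.

Compound 1 `COc1ccccc1Oc1c(N)nc(-c2cccc(Br)c2)nc1Cl` and compound 2 `COc1ccccc1Oc1c(N)nc(-c2ccc(Br)cc2)nc1Cl` share one core; in a functional assay on B16 cells (Mus musculus) for cytotoxicity, read by CCK-8 assay, with a stated time of 24 h (on this read-out higher numbers stand for weaker inhibition and lower numbers for stronger inhibition), compound 1 gives 24600 nM and compound 2 gives 4440 nM. The change between them is 4-bromophenyl in place of 3-bromophenyl on an aromatic carbon, and it brought a 5.5-fold lower number from compound 1 to compound 2 (0.74 log units; beyond the scatter). Compound 3 `COc1ccccc1Oc1c(N)nc(-c2cccc(Br)c2)nc1OCCO` carries a different core, the change being (2-hydroxyethoxy in place of chloro on an aromatic carbon), which gave a 1.1-fold lower number from compound 1 to compound 3 (0.05 log units; within the scatter); in this assay compound 3 gives 21900 nM. Compound 4 `COc1ccccc1Oc1c(N)nc(-c2ccc(Br)cc2)nc1OCCO` is not yet measured. It differs from compound 3 by 4-bromophenyl in place of 3-bromophenyl on an aromatic carbon, the same kind of change as the earlier one, though here the place is meta to a 2-hydroxyethoxy group and para to a 2-methoxyphenoxy group rather than meta to a chloro group. Resting on the step from compound 1 to compound 2, compound 4 is expected to show a 4.9-fold lower number from compound 3 to compound 4 (0.69 log units; beyond the scatter), an estimated 4500 nM in this assay, likely between 1800 nM and 11000 nM.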

Compound 4, half-maximal inhibitory concentration: 11800 nM
For compound 4 the middle estimate is 2.6-fold (0.42 log units) below the measured one, outside the stated range (above it).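

Putting 4-bromophenyl in place of 3-bromophenyl gave a 1.9-fold lower number from compound 3 to compound 4 (0.27 log units; within the scatter) in this assay, so the step seen on the chloro compounds did not carry over at the same size: the same change on two cores in this assay, a 5.5-fold lower number (0.74 log units; beyond the scatter) from compound 1 to compound 2 and a 1.9-fold lower number (0.27 log units; within the scatter) from compound 3 to compound 4, 3.0-fold (0.47 log units) apart, beyond the scatter of two such steps. Putting 2-hydroxyethoxy in place of chloro also depended on the core, giving a 2.7-fold higher number from compound 2 to compound 4 (0.42 log units; beyond the scatter): the same change on two cores in this assay, a 1.1-fold lower number (0.05 log units; within the scatter) from compound 1 to compound 3 and a 2.7-fold higher number (0.42 log units; beyond the scatter) from compound 2 to compound 4, 3.0-fold (0.47 log units) apart, beyond the scatter of two such steps. So in this set of four compounds, the result of each change depends on the other group present, but the data do not show why, nor how either change would behave on any other core.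

Still open, on these data alone, is how an amine or a longer chain in place of 2-hydroxyethoxy would behave with each bromophenyl group. Also open, as far as these compounds go, is whether a chlorophenyl group in place of bromophenyl would show the same dependence.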